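One Fluoro Fewer on a Compound at the Assay Limit

The source may hold more compounds than are shown below. What is called first, only, known or untested is meant among the compounds shown, and "the series" means these compounds.

In a functional assay on CCRF-CEM cells (Homo sapiens) for cytotoxicity, in the absence of a further agent (a lower number here means a stronger inhibitor, a higher number a weaker inhibitor), compound 1 (`COC(=O)c1ccc(CN(CCCc2c(N)nc(N)nc2O)c2cc(F)cc(F)c2[N+](=O)[O-])cc1`) gives > 100000 nM as its reading, which is a limit of the assay and not a number. Compound 2 (`Nc1nc(N)c(CCCN(Cc2ccc(NC(CCC(=O)O)C(=O)O)cc2)c2cc(F)cc(F)c2[N+](=O)[O-])c(O)n1`) gives > 100000 nM as its reading, again a limit. Within the data shown here, the one measured step is a step that the two limits leave unreadable from compound 1 to compound 2 and so offers no size to carry forward. The evidence amounts to the limit of > 100000 nM in this assay, at which 2 of the 2 values shown sit, and no more.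

Compound 3 (`COC(=O)c1ccc(CN(CCCc2c(N)nc(N)nc2O)c2cc(F)ccc2[N+](=O)[O-])cc1`) differs from compound 1 in a single place, hydrogen in place of fluoro on an aromatic carbon on an aromatic carbon ortho to a nitro group, where hydrogen stands in place of fluoro. An expectation can rest only on this small change. The expected step is a number no higher from compound 1 to compound 3 (the limit leaves the size open) in size, so none beyond the scatter in either direction, and another limit is the likeliest reading. For compound 3 the estimated value is 100000 nM with an expected range from 30000 nM to 200000 nM in this estimate.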

Compound 3, half-maximal inhibitory concentration: 45000 nM
Compound 3: middle estimate off by 2.2-fold (0.35 log units), on the high side, and the stated range covers the measured number.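

Removing the fluoro group ortho to a nitro group, which turns 3,5-difluoro-2-nitrophenyl into 5-fluoro-2-nitrophenyl, moves the reading in this assay off the limit, and the change is an at least 2.2-fold lower number from compound 1 to compound 3 (0.34 log units; beyond the scatter). Among these compounds, this position therefore affects the reading, even though the change removes only one heavy atom, and compound 3 gives the first actual number here, while the step between the two earlier compounds cannot be read. Compound 3 alone has such a number, and the rest of the evidence is still a limit: the limit of > 100000 nM in this assay, at which 2 of the 3 values shown sit.

The compounds shown leave open how a chloro group or a methoxy group at this position would read. Also open, going by these compounds, is whether the (1,3-dicarboxypropyl)amino group of compound 2 would give a measurable number on the 5-fluoro-2-nitrophenyl version.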